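The source may hold more compounds than are shown below. What is called first, only, known or untested is meant among the compounds shown, and "the series" means these compounds.

Within the data shown here, compound 1 `CCN(CC)CCCOc1cc2ncnc(Nc3nc4ccc(C(=O)Nc5c(C)cccc5C)cc4s3)c2cc1OC` is one of two compounds measured in a functional assay on K562 cells (Homo sapiens) for cytotoxicity, read by WST assay, with a stated time of 72 h; a higher number here means a weaker inhibitor, a lower number a stronger inhibitor. In this assay compound 1 gives 28400 nM, the highest of the two numbers on hand. Among the measured compounds shown here, the only other measured compound is compound 2 `COc1cc2c(Nc3nc4ccc(C(=O)Nc5c(C)cccc5C)cc4s3)ncnc2cc1OCCCN1CCC(C)CC1`, which in this assay gives 15800 nM. For the measured compounds named here, the single measured step, a 1.8-fold lower number from compound 1 to compound 2 (0.25 log units; within the scatter), changes the amine at the end of the chain that hangs from the shared core, and it stays within the scatter of the method.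

Compound 3 `CCN(CC)CCCOc1cc2ncnc(Nc3nc4ccc(C(=O)Nc5c(C)cc(C)cc5C)cc4s3)c2cc1OC` differs from compound 1 at a different end of the molecule: methyl in place of hydrogen on an aromatic carbon. Going by the values given here, no measured step touches this ring, so nothing on hand speaks directly to this change. Among the compounds with values here, the one step that exists, from compound 1 to compound 2, shows the shared core tolerating a small alteration without a shift beyond the scatter, and the added methyl is of a similar small size. The expectation is therefore a step of a 1.1-fold lower number from compound 1 to compound 3 (0.06 log units; within the scatter), with no direction claimed beyond the scatter. Compound 3 is estimated at 25000 nM, within a range from 9000 nM to 70000 nM.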

Compound 3, half-maximal inhibitory concentration: 6800 nM
Estimate against measurement, compound 3: 3.7-fold (0.57 log units) above, outside the stated range (below it).
By their numbers in this assay, from the lowest: compound 3; then compounds 2 and 1 (each within the scatter of the next).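

Among these compounds, the added methyl gives a 4.2-fold lower number from compound 1 to compound 3 (0.62 log units; beyond the scatter) in this assay, and this is the first step on hand that lies beyond the scatter. It shows that the aromatic carbon para to a large group and meta to two methyl groups is not a silent position: going from 2,6-dimethylphenyl to 2,4,6-trimethylphenyl, a change of 1 heavy atom, moves the number more than the swap of the amine at the other end of the molecule, which gives a 1.8-fold lower number from compound 1 to compound 2 (0.25 log units; within the scatter) and stays within the scatter. Nothing on hand offers an explanation for why this single methyl lowers the number.

The compounds shown leave open whether the lower number belongs to methyl itself or would also come with another group on this carbon, such as a chlorine atom, a methoxy group or an ethyl group, and whether the two methyl groups already on the ring matter for it. They also leave open whether the same added methyl would give a step of similar size on compound 2, which carries 4-methylpiperidin-1-yl in place of diethylamino.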